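From Acetamido to Amino: Compound 2 and Compound 4

The compounds below may be only part of what the source reports. "The series", "measured", "known", "first", "only" and "open" are said of these compounds alone.

In a physicochemical assay for solubility, read by nephelometry, measured as kinetic solubility (on this read-out lower numbers stand for lower solubility and higher numbers for higher solubility), compound 2 `CC(=O)Nc1cnc2[nH]c(=O)n([C@H]3CC[C@@H](C(C)C)CC3)c(=O)c2c1` gives 15000 nM, the lower of the two actual numbers, and its nearest neighbour, compound 3 `CC[C@H]1CC[C@@H](n2c(=O)[nH]c3ncc(NC(C)=O)cc3c2=O)CC1`, gives 48000 nM. Compound 1 `CC(=O)Nc1cnc2[nH]c(=O)n([C@H]3CC[C@@H](C(C)(C)C)CC3)c(=O)c2c1` reports only a limit, < 28000 nM. Compound 4 `CC(C)[C@H]1CC[C@@H](n2c(=O)[nH]c3ncc(N)cc3c2=O)CC1` differs from compound 2 by hydrogen in place of acetyl on a nitrogen on an aromatic ring, or acetamido to amino. Within the data shown here, no measured step touches this group, since all of them alter the saturated chain. Among the measured compounds shown here, the one readable step, a 3.2-fold higher number from compound 2 to compound 3 (0.51 log units; beyond the scatter), therefore serves only as a guide to scale. A modest upward change is expected, a 2.3-fold higher number from compound 2 to compound 4 (0.37 log units; beyond the scatter), though its direction is uncertain. Compound 4 is estimated at 35000 nM, with an expected range of 12000 nM to 100000 nM.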

Compound 4, solubility: 17000 nM
Compound 4: middle estimate off by 2.1-fold (0.31 log units), on the high side; measured number inside the range.
By their numbers in this assay, from the lowest: compounds 2 and 4 (each within the scatter of the next); then compound 3.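

Acetamido to amino, on a nitrogen on an aromatic ring, is the first change at this place, and in this assay it gives a 1.1-fold higher number from compound 2 to compound 4 (0.05 log units; within the scatter), so compound 2 and compound 4 cannot be told apart on this read-out. Among these compounds, the earlier steps altered only the saturated chain, where the one readable step, a 3.2-fold higher number from compound 2 to compound 3 (0.51 log units; beyond the scatter), lies beyond the scatter. No measurement shown bears on why acetyl and hydrogen read alike here.

Still open, on these data alone, is how other groups on that nitrogen, such as a methylsulfonyl or a longer acyl chain, would read. Also open, as far as these compounds go, is whether amino reads the same with ethyl or tert-butyl on the saturated ring carbon.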